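Nitro for trifluoromethyl on the benzamide of compound 3

The compounds below may be only part of what the source reports. "The series", "measured", "known", "first", "only" and "open" are said of these compounds alone.

Compound 3 `O=C(Nc1nc(-c2ccccc2)nc2c1nnn2Cc1ccccc1)c1ccc(C(F)(F)F)cc1` gives 123 nM in an assay (strain Wistar) for displacement of a labelled ligand from adenosine receptor A1 (Rattus norvegicus), read by scintillation counting (on this read-out lower numbers stand for stronger inhibition and higher numbers for weaker inhibition), the highest of the three numbers in hand. Compound 1 `O=C(Nc1nc(-c2ccccc2)nc2c1nnn2Cc1ccccc1)c1cccc([N+](=O)[O-])c1` gives 77 nM, and a 1.6-fold higher number from compound 1 to compound 3 (0.20 log units; within the scatter). Compound 2 `O=C(Nc1nc(-c2ccccc2)nc2c1nnn2Cc1ccccc1)c1ccoc1` gives 10 nM, and a 12-fold higher number from compound 2 to compound 3 (1.09 log units; beyond the scatter). Compound 4 `O=C(Nc1nc(-c2ccccc2)nc2c1nnn2Cc1ccccc1)c1ccc([N+](=O)[O-])cc1` differs from compound 3 by nitro in place of trifluoromethyl on an aromatic carbon. Among the compounds with values here, no measured step makes exactly this change; the nearest is a 1.6-fold higher number from compound 1 to compound 3 (0.20 log units; within the scatter), which swaps 3-nitrophenyl for 4-(trifluoromethyl)phenyl and stays within the scatter. On that basis compound 4 is expected to land close to compound 3, with a step of a 1.4-fold lower number from compound 3 to compound 4 (0.14 log units; within the scatter) in this assay, not clearly beyond the scatter. The estimate for compound 4 is 90 nM, between 30 nM and 270 nM.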

Compound 4, inhibition constant: 24 nM
Compound 4: middle estimate off by 3.8-fold (0.57 log units), on the high side; the measured number lies below the stated range.
By their numbers in this assay, from the lowest: compound 2; then compound 4; then compounds 1 and 3 (each within the scatter of the next).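

In this assay the group on this phenyl ring clearly matters: nitro in place of trifluoromethyl gives a real gain (a 5.1-fold lower number from compound 3 to compound 4 (0.71 log units; beyond the scatter)), although 3-nitrophenyl and 4-(trifluoromethyl)phenyl had not separated. The place of the nitro also counts, as 4-nitrophenyl in place of 3-nitrophenyl shows (a 3.2-fold lower number from compound 1 to compound 4 (0.51 log units; beyond the scatter)). Furan-3-yl still keeps the lowest number (a 2.4-fold higher number from compound 2 to compound 4 (0.38 log units; beyond the scatter)). On these data alone, whether an amine or a carboxylic acid in place of nitro on that ring would keep the gain remains open. No measurement here accounts for these steps.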